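A propyl chain becomes an allyl chain

This account rests on a few compounds, and the source may have more. Where it says the series, first, only, none or still open, it means among the compounds named here.

In a functional assay on the whole organism for inhibition, with Mus musculus as the target (a higher number here means that more compound is needed for the effect, a lower number that less compound is needed), compound 1 `CC1=CC(N)=NCC1(C)C` gives 0.28 mg/kg and compound 2 `CCCC1CC(C)=CC(N)=N1` gives 0.36 mg/kg so these two values lie within the usual scatter of each other. Compound 3 `C=CCC1CC(C)=CC(N)=N1` differs from compound 2 in one place vinyl in place of ethyl on a saturated chain carbon bound to a saturated ring carbon with vinyl in place of ethyl on a saturated chain carbon bound to a saturated ring carbon. Within the data shown here, no measured pair shows the effect of this change in this assay so no shift beyond the scatter is expected. The estimated 1.0-fold lower number from compound 2 to compound 3 (0.01 log units; within the scatter) is therefore small. Compound 3 is expected at 0.35 mg/kg with an estimated range of 0.15 mg/kg to 0.8 mg/kg in this test.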

Compound 3, dose for 50% inhibition: 0.16 mg/kg
The estimate for compound 3 lay 2.2-fold (0.34 log units) above the measured number; measured number inside the range.
By their numbers in this assay, from the lowest: compounds 3, 1 and 2 (each within the scatter of the next, the first and the last beyond it).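

Replacing the propyl chain with an allyl chain keeps the same count of heavy atoms and adds a double bond, yet it gives a 2.3-fold lower number from compound 2 to compound 3 (0.35 log units; beyond the scatter) in this assay. Among these compounds, this is the first sign that the dose needed responds to the make-up of this chain and not only to its size, though the step is modest. Nothing available explains the shift. On these data alone, whether a longer chain, a phenyl group or an amine in this place would lower the number further remains open, and so does whether one step on this core applies to others.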